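The source may hold more compounds than are shown below. What is called first, only, known or untested is meant among the compounds shown, and "the series" means these compounds.

Three compounds on a shared core have numbers in an ADME assay on S9 fraction from S9 cells (Zone of skin, Homo sapiens) for metabolic stability, read by HPLC, with a stated time of 180 min, tested at 0.5 uM; a lower number here means that the compound disappears faster, a higher number that the compound lasts longer: compound 1 (`CCC/N=C1\S/C(=C\c2ccc(OC(=O)C(C)C)c(C)c2)C(=O)N1c1ccccc1C`) gives 0.35 h of half-life, compound 2 (`CCC/N=C1\S/C(=C\c2ccc(OC(=O)CCO)c(C)c2)C(=O)N1c1ccccc1C`) gives 0.137 h and compound 3 (`CCC/N=C1\S/C(=C\c2ccc(OC(=O)CCOC)c(C)c2)C(=O)N1c1ccccc1C`) gives 0.08 h on the same read-out. Compound 3 stands level with compound 2 (a 1.7-fold lower number from compound 2 to compound 3 (0.23 log units; within the scatter)) but clearly apart from compound 1 (a 4.4-fold lower number from compound 1 to compound 3 (0.64 log units; beyond the scatter)).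

Compound 4 (`CCC/N=C1\S/C(=C\c2ccc(OC(C)=O)c(C)c2)C(=O)N1c1ccccc1C`) has hydrogen in place of methoxymethyl on a saturated chain carbon bound to a carbonyl carbon, which turns 2-methoxyethyl into methyl. For the measured compounds named here, no measured step makes this exact change. The closest guides are the two modest steps away from isopropyl (a 2.6-fold lower number from compound 1 to compound 2 (0.41 log units; beyond the scatter)) and (a 4.4-fold lower number from compound 1 to compound 3 (0.64 log units; beyond the scatter)), both beyond the scatter. Methyl, like the isopropyl of compound 1, holds no oxygen, so part of that loss is expected to return in this assay. A modest upward move is expected (a 2.1-fold higher number from compound 3 to compound 4 (0.33 log units; beyond the scatter)). Compound 4 is estimated at 0.17 h within an expected range (0.08 h to 0.35 h).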

Compound 4, half-life: 0.122 h
Compound 4: middle estimate off by 1.4-fold (0.14 log units), on the high side, within the range that was stated.
By their numbers in this assay, from the lowest: compounds 3, 4 and 2 (each within the scatter of the next); then compound 1.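

At the saturated chain carbon bound to the carbonyl carbon, methyl sits level with both oxygen-bearing chains in this assay, (a 1.5-fold higher number from compound 3 to compound 4 (0.18 log units; within the scatter)) and (a 1.1-fold lower number from compound 2 to compound 4 (0.05 log units; within the scatter)), so these three groups are not separated. Only isopropyl stands apart (a 2.9-fold lower number from compound 1 to compound 4 (0.46 log units; beyond the scatter)), which shows that the lower numbers seen with 2-hydroxyethyl and 2-methoxyethyl do not require an oxygen in the chain. No measurement at hand accounts for the gap between isopropyl and the other three groups.

Going by these compounds, it remains open whether the number of compound 1, 0.35 h, is particular to isopropyl or is shared by other branched groups such as tert-butyl or cyclopropyl. On these data alone, a longer chain such as n-butyl, or an amine on the chain, also remains untested against these four compounds.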